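A few compounds are considered here, and "the series" means these few. Any claim that something is new, unique, unknown or untested is made for them only; others in the source may bear on it.

Measured compounds:
Compound 1 `Oc1ccccc1-c1cncnc1`: in a functional assay on HT-29 cells (Homo sapiens) for cytotoxicity, read by MTT assay, with a stated time of 2 days (a lower number here means a stronger inhibitor, a higher number a weaker inhibitor), compound 1 gives 380000 nM.
Compound 2 `COc1ccc(-c2cncnc2)cc1OC`: in this assay compound 2 reaches only the limit of > 400000 nM.
Compound 3 `COc1ccc(-c2cccnc2)cc1OC`: in this assay compound 3 likewise reaches only the limit of > 400000 nM.

For the measured compounds named here, compound 1 is the only compound of the three to give a number in this assay; the other two sit at the limit of > 400000 nM in this assay, at which 2 of the 3 values shown sit, so compound 1 cannot be ordered against them, and the number it gives is itself very weak. The series shares a core carrying a six-membered aromatic ring of carbon only; compound 1 bears a hydroxy on it, compound 2 and compound 3 two methoxy groups.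

Compound 4 `c1ccc(-c2cncnc2)cc1` differs from compound 1 by hydrogen in place of hydroxy on an aromatic carbon. Going by the values given here, no step between measured compounds is available to calibrate this change, so no direction beyond the scatter is expected; the step from compound 1 to compound 4 is estimated to be a 1.1-fold higher number from compound 1 to compound 4 (0.02 log units; within the scatter). Compound 4 is therefore expected to give about 400000 nM in this assay, somewhere between 150000 nM and 1000000 nM, with a fair chance that the assay reports only a limit.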

Compound 4, half-maximal inhibitory concentration: > 400000 nM
Compound 4 gave a limit, no number; the forecaster's own chance of this, stated with the estimate: 55%; the middle value lies on the limit itself.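

With hydrogen in place of hydroxy on an aromatic carbon, compound 4 gives > 400000 nM, which is a limit of the assay and not a number. In this assay this change at the position ortho to a group of 6 heavy atoms reads as an at least 1.0-fold higher number from compound 1 to compound 4 (0.02 log units; that floor lies within the scatter), so it provides a step for this position but only a floor for its size, and it shows no gain in strength on losing the hydroxy. The values in the series now gather at one limit, which leaves little room for comparison: the limit of > 400000 nM in this assay, at which 3 of the 4 values shown sit.

Going by these compounds, whether an amine or a carboxylic acid at this position would give a clearly lower number remains open. On these data alone, how far the true value of compound 4 lies from that of compound 1 also remains open.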